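Benzyl pyrazole substituents on a shared core: adenosine A2b binding

The source may hold more compounds than are shown below. What is called first, only, known or untested is meant among the compounds shown, and "the series" means these compounds.

Measured so far in an in vitro assay on HEK293 cells for displacement of a labelled ligand from adenosine receptor A2b (Homo sapiens); on this read-out lower numbers stand for stronger inhibition and higher numbers for weaker inhibition:
- compound 1 `CCCn1c(=O)c2nc(-c3cnn(Cc4cc(Cl)ccc4Cl)c3)[nH]c2n(CCC)c1=O`: 29 nM
- compound 2 `CCCn1c(=O)c2nc(-c3cc(C)nn3CC)[nH]c2n(CCC)c1=O`: 2100 nM
- compound 3 `CCn1c(=O)c2nc(-c3cnn(Cc4ccccc4)c3)[nH]c2n(CC)c1=O`: 19 nM

Compound 1 sits second highest of the three numbers. Its nearest neighbour is compound 3, whose number lies within the scatter of that of compound 1; the two cannot be ordered on these data. Compound 2 stands far beyond the scatter, with a much higher number in this assay than compound 1.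

Compound 4 `CCCn1c(=O)c2nc(-c3cnn(Cc4ccc(F)c(C(F)(F)F)c4)c3)[nH]c2n(CCC)c1=O` has not been measured. It differs from compound 1 in one place: 4-fluoro-3-(trifluoromethyl)phenyl in place of 2,5-dichlorophenyl on a saturated chain carbon bound to an aromatic nitrogen. The group that leaves and the group that enters are both six-membered aromatic rings of carbon only, each with no hydrogen-bond donors or acceptors and no net charge; the ring that enters carries three more heavy atoms.

Among the measured compounds shown here, no measured pair in this set shows the effect of such an exchange. Since compound 1 and compound 3 give numbers within the scatter of each other despite differing at this part of the molecule, the step from compound 1 to compound 4 is expected to be small, most likely none beyond the scatter, and is estimated as a 1.2-fold higher number from compound 1 to compound 4 (0.08 log units; within the scatter). Compound 4 is expected to give 35 nM in this assay, within the range 10 nM to 120 nM.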

Compound 4, inhibition constant: 640 nM
For compound 4 the middle estimate is 18-fold (1.26 log units) below the measured one, outside the stated range (above it).
By their numbers in this assay, from the lowest: compounds 3 and 1 (each within the scatter of the next); then compound 4; then compound 2.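

In this assay, the aryl group on a saturated chain carbon bound to an aromatic nitrogen proves sensitive to substitution: 4-fluoro-3-(trifluoromethyl)phenyl in place of 2,5-dichlorophenyl gives a 22-fold higher number from compound 1 to compound 4 (1.34 log units; beyond the scatter) and marks this exchange as a large one for the series. As the only single-place step shown, it establishes that these two substituted phenyl rings, each with no hydrogen-bond donors or acceptors and no net charge, are not interchangeable at this position. No measurement at hand accounts for the size of this step.

The compounds shown leave open whether the step follows from losing the chlorines, from gaining the fluoro group, or from gaining the trifluoromethyl group. Also open, from the compounds shown here alone, is how a methoxy group on the phenyl ring, or a pyridine ring in place of it, would behave at this position.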